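Ester-for-amide swap on the benzyl ester side chain

A few compounds are considered here, and "the series" means these few. Any claim that something is new, unique, unknown or untested is made for them only; others in the source may bear on it.

Values measured in a functional assay on HeLa cells (Homo sapiens) for antiproliferative activity, read by MTT assay, with a stated time of 48 h; a higher number here means a weaker inhibitor, a lower number a stronger inhibitor:
- compound 1, `C[C@H](NC(=O)c1cc2ccccc2cn1)C(=O)OCc1ccccc1`: 154 nM
- compound 2, `O=C(C[C@@H]1CCCN1C(=O)c1cc2ccccc2cn1)OCc1ccccc1`: 87.7 nM
- compound 3, `NC(=O)CC[C@H](NC(=O)c1cc2ccccc2cn1)C(=O)OCc1ccccc1`: 181 nM

Compound 3 stands highest of the three numbers in this assay. Its nearest neighbour is compound 1: the step of a 1.2-fold higher number from compound 1 to compound 3 (0.07 log units; within the scatter), i.e. carbamoylmethyl in place of hydrogen on a saturated chain carbon, two bonds along the chain from an amide-type nitrogen and a carbonyl carbon. Compound 2 differs from compound 3 in more than one place; its number is lower and the two values lie apart by more than the scatter.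

Compound 4, `O=C(CC[C@H](NC(=O)c1cc2ccccc2cn1)C(=O)OCc1ccccc1)OCc1ccccc1`, is not yet measured. It differs from compound 3 by benzyloxy in place of amino on a carbonyl carbon, that is, carbamoyl becomes benzyloxycarbonyl on the side chain. For the measured compounds named here, no measured step changes an amide to an ester; the only step that touches this side chain, a 1.2-fold higher number from compound 1 to compound 3 (0.07 log units; within the scatter), shows that adding the carbamoylmethyl group itself left the number within the scatter. On that basis the change is expected to be small: a 1.2-fold lower number from compound 3 to compound 4 (0.08 log units; within the scatter) is the expected step, with no clear direction. Compound 4 is therefore estimated at 150 nM in this assay, with a range from 70 nM to 330 nM.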

Compound 4, half-maximal inhibitory concentration: 214 nM
For compound 4 the middle estimate is 1.4-fold (0.15 log units) below the measured one, and the stated range covers the measured number.
By their numbers in this assay, from the lowest: compounds 2, 1, 3 and 4 (each within the scatter of the next, the first and the last beyond it).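

In this assay, for the compounds shown here, benzyloxy in place of amino on the carbonyl carbon gives a 1.2-fold higher number from compound 3 to compound 4 (0.07 log units; within the scatter) and is the first amide-to-ester change read at this position; it brings in a six-membered aromatic ring and loses a hydrogen-bond donor, yet the number stays within the scatter. The whole (benzyloxycarbonyl)methyl group in place of hydrogen on the saturated chain carbon gives a 1.4-fold higher number from compound 1 to compound 4 (0.14 log units; within the scatter) and is also within the scatter, so compounds 1, 3 and 4 cannot be told apart by these steps, even with this larger group on the chain. Nothing measured here accounts for this result.

From the compounds shown here alone, whether a free carboxylic acid, an amine or a longer chain at this position would move the number beyond the scatter remains open. Compound 2 differs from compound 3 in more than one place, so these steps do not show what sets its number apart.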